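The compounds below may be only part of what the source reports. "The series", "measured", "known", "first", "only" and "open" are said of these compounds alone.

Measured in a functional assay on K562 cells (Homo sapiens) for inhibition, read by CellTiter-Glo, with a stated time of 48 h; on this read-out lower numbers stand for stronger inhibition of growth and higher numbers for weaker inhibition of growth:

- compound 1 `O=C(CCCCC(=O)N1C/C=C/COCc2cccc(c2)-c2ccnc(n2)Nc2cccc(c2)C1)NO`: 4970 nM
- compound 2 `O=C(CCCCCCN1C/C=C/COCc2cccc(c2)-c2ccnc(n2)Nc2cccc(c2)C1)NO`: 940 nM
- compound 3 `O=C(CCCCCCC(=O)N1C/C=C/COCc2cccc(c2)-c2ccnc(n2)Nc2cccc(c2)C1)NO`: 4390 nM

Compound 3, at 4390 nM, cannot be told apart from compound 1, which gives 4970 nM. Among these three compounds, the clear gaps involve compound 2, which gives 940 nM.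

The next compound to be tested is compound 4 `O=C(CCCCCCCC(=O)N1C/C=C/COCc2cccc(c2)-c2ccnc(n2)Nc2cccc(c2)C1)NO`. It differs from compound 3 only in the chain that carries the hydroxycarbamoyl group: (hydroxycarbamoyl)methyl in place of hydroxycarbamoyl on a saturated chain carbon, six bonds along the chain from a carbonyl carbon. The carbonyl on the amine nitrogen in the ring stays in place.

One measured step is a chain extension of the same kind, with that carbonyl retained: a 1.1-fold lower number from compound 1 to compound 3 (0.05 log units; within the scatter). That step lies within the scatter. The two larger steps, a 5.3-fold lower number from compound 1 to compound 2 (0.72 log units; beyond the scatter) and a 4.7-fold higher number from compound 2 to compound 3 (0.67 log units; beyond the scatter), each involve a compound without that carbonyl, so they bear on compound 4 only indirectly. Among the compounds with values here, no compound with a chain longer than that of compound 3 has yet been measured, so this expectation rests on a single comparison.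

No change beyond the scatter is therefore expected in this assay, in either direction. The expected change is a 1.1-fold lower number from compound 3 to compound 4 (0.04 log units; within the scatter). Compound 4 is estimated at 4000 nM, with an expected range of 1800 nM to 9000 nM.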

Compound 4, concentration for 50% growth inhibition: 2640 nM
The estimate for compound 4 lay 1.5-fold (0.18 log units) above the measured number; low and high end bracket the measured number.
By their numbers in this assay, from the lowest: compound 2; then compounds 4, 3 and 1 (each within the scatter of the next).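

In this assay, lengthening the chain at this position while keeping the carbonyl on the amine nitrogen in the ring gives a 1.7-fold lower number from compound 3 to compound 4 (0.22 log units; within the scatter), and the widest comparison in this carbonyl series gives a 1.9-fold lower number from compound 1 to compound 4 (0.27 log units; within the scatter). Within the data shown here, with compound 4 added, three chain lengths carrying that carbonyl can be compared, and compounds 1, 3 and 4 cannot be told apart, so the earlier single comparison between compound 1 and compound 3 now extends to a further chain length, with no compound going against it. Nothing available explains why chain length at this position leaves the number within the scatter in this series.

As far as these compounds go, it remains open whether a chain longer than that of compound 4 would keep the number within the same scatter, or whether the series would change beyond it. Also open, from the compounds shown here alone, are how chains of other lengths without the carbonyl, like that of compound 2, would compare, and whether a carboxylic acid or a primary amide in place of the hydroxycarbamoyl group on these chains would hold the number.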